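This account rests on a few compounds, and the source may have more. Where it says the series, first, only, none or still open, it means among the compounds named here.

Measured so far, in a functional assay on DU-145 cells (Homo sapiens) for cytotoxicity, read by trypan blue exclusion, with a stated time of 96 h; a lower number here means a stronger inhibitor, a higher number a weaker inhibitor:
- compound 1 `COc1cc(OC)c(/C=C/S(=O)(=O)Nc2ccc(OC)c(O)c2)c(OC)c1`: 30 nM
- compound 2 `COC(=O)CNc1cc(NS(=O)(=O)/C=C/c2c(OC)cc(OC)cc2OC)ccc1OC`: 350 nM

Compound 2 has the higher of the two numbers, at 350 nM. Compound 3 `COC(=O)C(Nc1cc(NS(=O)(=O)/C=C/c2c(OC)cc(OC)cc2OC)ccc1OC)c1ccc(F)cc1` differs from it by one change: 4-fluorophenyl in place of hydrogen on a saturated chain carbon bound to a carbonyl carbon and a nitrogen on an aromatic ring. In words, this is 4-fluorophenyl in place of hydrogen on a saturated chain carbon bound to a carbonyl carbon and a nitrogen on an aromatic ring.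

Among the compounds with values here, the only measured step, a 12-fold higher number from compound 1 to compound 2 (1.07 log units; beyond the scatter), is large and beyond the scatter. It introduced the (methoxycarbonyl)methyl chain that now changes, so it bears on this change only indirectly. Within the data shown here, no measured compound carries 4-fluorophenyl, and the direction stays open. In this assay, no step beyond the scatter is expected, and the estimated step is a 1.1-fold higher number from compound 2 to compound 3 (0.06 log units; within the scatter). For compound 3 the estimate is 400 nM, with an expected range of 80 nM to 2000 nM.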

Compound 3, half-maximal inhibitory concentration: 2500 nM
Compound 3: middle estimate off by 6.3-fold (0.80 log units), on the low side; the measured number lies above the stated range.
By their numbers in this assay, from the lowest: compound 1; then compound 2; then compound 3.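

In this assay, the saturated chain carbon bound to a carbonyl carbon and a nitrogen on an aromatic ring does not accept substitution without consequence: 4-fluorophenyl in place of hydrogen gives a 7.1-fold higher number from compound 2 to compound 3 (0.85 log units; beyond the scatter) and so moves the series further from compound 1. The (methoxycarbonyl)methyl chain had already brought a 12-fold higher number from compound 1 to compound 2 (1.07 log units; beyond the scatter) and its substitution adds a second step in the same direction, so neither change on this part of the series has yet lowered the number. Nothing among the available data speaks to the reason for this new step.

As far as these compounds go, whether the step belongs to the ring or to its fluorine stays open, and a plain phenyl or a methyl on the same carbon would help to separate these. From the compounds shown here alone, how a carboxylic acid in place of the methyl ester would read on this chain also remains open.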